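Chloro for Nitro on a Core Where Every Value Is a Limit

The source may report more compounds than this note shows. Statements on the series, on what has been measured and on what is new or still open speak of the compounds shown alone.

Three compounds share one core and differ only in a substituted phenyl group. Among the compounds with values here, compound 1 `O=c1ccoc2cc(OCc3cn(Cc4ccc([N+](=O)[O-])cc4)nn3)ccc12` is the first. In a functional assay on SGC-7901 cells (Homo sapiens) for cytotoxicity, read by MTT assay, with a stated time of 48 h (on this read-out lower numbers stand for stronger inhibition and higher numbers for weaker inhibition), compound 1 reaches only a limit of the assay, > 100000 nM. Compound 2 `O=c1ccoc2cc(OCc3cn(Cc4ccccc4)nn3)ccc12` has hydrogen in place of nitro on an aromatic carbon. In this assay compound 2 reaches only the limit, > 100000 nM. Compound 3 `O=c1ccoc2cc(OCc3cn(Cc4cccc([N+](=O)[O-])c4)nn3)ccc12` carries 3-nitrophenyl in place of 4-nitrophenyl on a saturated chain carbon bound to an aromatic nitrogen. In this assay compound 3 stops at the limit, > 100000 nM. The steps a step that the two limits leave unreadable from compound 1 to compound 2, a step that the two limits leave unreadable from compound 1 to compound 3 and a step that the two limits leave unreadable from compound 2 to compound 3 are of unreadable size, as all three values sit at the limit of > 100000 nM in this assay, at which 3 of the 3 values shown sit.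

Compound 4 `O=c1ccoc2cc(OCc3cn(Cc4cccc(Cl)c4)nn3)ccc12` follows from compound 3 by chloro in place of nitro on an aromatic carbon. The step that the two limits leave unreadable from compound 2 to compound 3 touches the same nitro group, yet its size cannot be read, so no direction is known; the step that the limit leaves unreadable from compound 3 to compound 4 is expected only as a formal value. Compound 4 is expected to give about 150000 nM, within 40000 nM to 500000 nM, most probably again a limit.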

Compound 4, half-maximal inhibitory concentration: > 100000 nM
Compound 4: no number, only a limit; the forecaster's own chance of this, stated with the estimate: 85%; the middle value is on the limit's open side.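

In this assay compound 4 also gives only a limit, > 100000 nM. Within the data shown here, no step from compound 1, compound 2 or compound 3 to compound 4 can be read. The compounds shown leave open how the four compare in this read-out, and whether changing the phenyl substituent alters it at all.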